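The compounds below may be only part of what the source reports. "The series", "measured", "known", "first", "only" and "open" are said of these compounds alone.

In a functional assay on MCF7 cells (Homo sapiens) for antiproliferative activity, read by MTT assay, with a stated time of 24 h (on this read-out higher numbers stand for weaker inhibition and lower numbers for stronger inhibition), three compounds sharing one core have results so far. Compound 1 (`Cc1ccc(-c2nn(-c3ccccc3)cc2-c2nc3ccccc3n2S(=O)(=O)c2ccc(F)cc2)cc1`) gives 5270 nM as the highest of the three numbers. Compound 2 (`Cc1ccc(-c2nn(-c3ccccc3)cc2-c2nc3ccccc3n2S(=O)(=O)c2ccc(Br)cc2)cc1`) stands at 3160 nM and compound 3 (`Cc1ccc(-c2nn(-c3ccccc3)cc2-c2nc3ccccc3n2S(=O)(=O)c2ccc(C(F)(F)F)cc2)cc1`) at 2340 nM on the same scale. Compound 4 (`O=S(=O)(c1ccc(F)cc1)n1c(-c2cn(-c3ccccc3)nc2-c2ccc(F)cc2)nc2ccccc21`) has not yet been measured. It differs from compound 1 by one change (fluoro in place of methyl on an aromatic carbon) in which fluoro takes the place of methyl on an aromatic carbon, turning 4-methylphenyl into 4-fluorophenyl. The measured steps all concern another group of the molecule, so they bear on this change only indirectly. Bromo in place of fluoro gave a 1.7-fold lower number from compound 1 to compound 2 (0.22 log units; within the scatter) and trifluoromethyl in place of bromo gave a 1.4-fold lower number from compound 2 to compound 3 (0.13 log units; within the scatter) as its result. Trifluoromethyl in place of fluoro is the remaining swap. Since the step of a 2.3-fold lower number from compound 1 to compound 3 (0.35 log units; beyond the scatter) is only modest, no step beyond the scatter is expected in this assay for the new swap. For the measured compounds named here, none of the measured steps replaces methyl, so the data show no direction for it. The expected result is a 1.2-fold lower number from compound 1 to compound 4 (0.07 log units; within the scatter) with its direction uncertain. In this assay the estimated value for compound 4 is 4500 nM with an expected range from 2000 nM to 10000 nM around it.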

Compound 4, half-maximal inhibitory concentration: 3670 nM
Compound 4: middle estimate off by 1.2-fold (0.09 log units), on the high side, and the stated range covers the measured number.
By their numbers in this assay, from the lowest: compounds 3, 2, 4 and 1 (each within the scatter of the next, the first and the last beyond it).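

In this assay, putting fluoro in place of methyl, which turns 4-methylphenyl into 4-fluorophenyl, gives a 1.4-fold lower number from compound 1 to compound 4 (0.16 log units; within the scatter). For the compounds shown here, this is the first information on this position, as the earlier compounds varied only a group elsewhere in the molecule: on this single pair, swapping one small group for another on an aromatic carbon, para to a large group, does not move the number beyond what repeated measurements would scatter by. No measurement is available that could explain this result.

Going by these compounds, with only methyl and fluoro seen at this position, it remains open whether a group of another kind, such as an amine, a carboxylic acid, a methoxy group or a longer alkyl chain, would shift the number beyond the scatter in either direction. It is also open whether the same swap would give a similar result when the other group is bromo, as in compound 2, or trifluoromethyl, as in compound 3, since the only pair shown for this swap carries fluoro there.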